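Working notes: from compound 2 to compound 4

This account rests on a few compounds, and the source may have more. Where it says the series, first, only, none or still open, it means among the compounds named here.

Measured so far in a functional assay for inhibition, with Homo sapiens as the target; a lower number here means a stronger inhibitor, a higher number a weaker inhibitor:
compound 1 `CSc1nncc2c(C)nc(C)n12` gives > 48000 nM, which is a limit of the assay and not a number.
compound 2 `CCCc1ncc2cnnc(SC)n12` gives > 48000 nM, a limit of the assay.
compound 3 `C=CCSc1nncc2cnc(CCC)n12` gives > 48000 nM, again a limit of the assay.

Compound 2 therefore stands nowhere definite on the numbers shown: its value is a limit only, and the two further values shown are limits as well. Within the data shown here, the single step between measured compounds, a step that the two limits leave unreadable from compound 2 to compound 3, cannot be sized because the limit of > 48000 nM in this assay, at which 3 of the 3 values shown sit, holds both of its ends.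

The step under consideration goes from compound 2 to compound 4 `CSc1nncc2cnc(C)n12`, with the change (hydrogen in place of ethyl on a saturated chain carbon bound to an aromatic carbon). Among the measured compounds shown here, no measured step touches this place; the one readable pair concerns the sulfur side of the shared core, and it is unreadable in any case. For the measured compounds named here, nothing among the measured compounds points to inhibition appearing on this change, since every value shown is a limit.

Compound 4 is accordingly expected to sit at 100000 nM, with a range from 30000 nM to 500000 nM. The expected step from compound 2 to compound 4 is a step that the limit leaves unreadable from compound 2 to compound 4, most likely reported as a limit rather than a number.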

Compound 4, half-maximal inhibitory concentration: > 48000 nM
Compound 4: no number, only a limit (the forecaster's own chance of this, stated with the estimate: 85%); the middle value is on the limit's open side.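

In this assay compound 4 gives > 48000 nM, a limit of the assay and not a number, so the steps to compound 4 from compound 1 and from compound 2 cannot be read: the limit of > 48000 nM in this assay, at which 4 of the 4 values shown sit. The compounds shown leave open how strongly any of them inhibits in this assay, and whether any change on the shared core alters that.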